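From Iodo to Cyano on a Shared Core

The source may report more compounds than this note shows. Statements on the series, on what has been measured and on what is new or still open speak of the compounds shown alone.

Of the compounds shown here, three sharing one core have been read in a functional assay on MDA-MB-468 cells (Homo sapiens) for inhibition; on this read-out higher numbers stand for weaker inhibition and lower numbers for stronger inhibition. In this assay compound 1 `CCc1cc(N)ccc1-c1nc2ccccc2s1` gives < 0.1 nM, which is a limit and not a number. In this assay compound 2 `Nc1ccc(-c2nc3ccccc3s2)c(I)c1` gives < 0.1 nM, again a limit. In this assay compound 3 `Cc1ccc2nc(-c3ccc(N)cc3I)sc2c1` gives < 0.1 nM, also a limit. Compound 2 thus has no exact number, and the whole set amounts to the limit of < 0.1 nM in this assay, at which 3 of the 3 values shown sit.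

Compound 4 `N#Cc1cc(N)ccc1-c1nc2ccccc2s1` has not yet been measured. It differs from compound 2 by cyano in place of iodo on an aromatic carbon, ortho to a group of 9 heavy atoms and meta to an amino group.

Among the compounds with values here, two measured steps bear on this change. The closer is a step that the two limits leave unreadable from compound 1 to compound 2, as it also involves the iodo group that cyano would replace. The other is a step that the two limits leave unreadable from compound 2 to compound 3, a methyl in place of hydrogen on an aromatic carbon. Neither has a readable size, so neither can be carried over as a number. Ethyl and iodo both leave the read-out at the limit, but cyano is untested here, so some weakening is expected. The expected change is an at least 5.0-fold higher number from compound 2 to compound 4 (0.69 log units; beyond the scatter), towards weaker inhibition, and it is only loosely estimated. For compound 4 the estimated value is 0.5 nM, with an expected range from 0.05 nM to 10 nM.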

Compound 4, half-maximal inhibitory concentration: < 0.1 nM
Compound 4 ended at the assay's limit; the forecaster's own chance of this, stated with the estimate: 40%; at least 5.0-fold (0.69 log units) between middle value and limit.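

In this assay compound 4 gives < 0.1 nM, which is a limit and not a number. The steps to compound 4 from compound 1 and from compound 2 therefore cannot be read. The compounds shown leave open whether ethyl, iodo and cyano differ at all on this read-out, as the whole set stands at: the limit of < 0.1 nM in this assay, at which 4 of the 4 values shown sit.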